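Cytotoxicity notes on the urea series and one new analogue

The source may report more compounds than this note shows. Statements on the series, on what has been measured and on what is new or still open speak of the compounds shown alone.

Measured compounds in an ADME assay on BJ cells (Homo sapiens) for cytotoxicity, with a stated time of 72 h; on this read-out higher numbers stand for an effect only at larger amounts of compound and lower numbers for an effect already at smaller amounts:
compound 1 `COc1ccc(NC(=O)Nc2cc(C)nc3ccccc23)cc1OC`, compound 1 gives > 25000 nM, a limit of the assay rather than a number.
compound 2 `Cc1cc(NC(=O)Nc2ccc(N(C)C)cc2)c2ccccc2n1`, compound 2 gives > 25000 nM, likewise a limit.
compound 3 `COc1ccc(NC(=O)Nc2cc(C)nc3ccccc23)cc1F`, compound 3 gives 26000 nM.

Among the compounds with values here, the only step measured, a step that the limit leaves unreadable from compound 1 to compound 3, stays unreadable because the limit of > 25000 nM in this assay, at which 2 of the 3 values shown sit, hides its size. Compound 2 stands at that same limit, together with compound 1, so its position is known only as a limit.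

Compound 4 `Cc1cc(NC(=O)Nc2ccc(N)cc2)c2ccccc2n1` differs from compound 2 by amino in place of dimethylamino on an aromatic carbon. Within the data shown here, no measured step covers this exchange; the one measured step concerns a different change and cannot be sized. Nothing therefore points to a step beyond the scatter in this assay. Compound 4 is expected to give about 25000 nM, between 10000 nM and 60000 nM, most likely again as a limit. The expected step is a number no higher from compound 2 to compound 4 (the limit leaves the size open), within scatter.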

Compound 4, half-maximal effective concentration: > 25000 nM
Compound 4: only a limit was reported; the forecaster's own chance of this, stated with the estimate: 65%; the middle value lies on the limit itself.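

No step can be read from compound 2 to compound 4, since both stand at a limit: the limit of > 25000 nM in this assay, at which 3 of the 4 values shown sit.

From the compounds shown here alone, how far compound 1, compound 2 and compound 4 lie past that limit stays open, and with it any effect of amino in place of dimethylamino.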